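Replacing the nitro group of a styryl cinnamamide with fluorine

The compounds below may be only part of what the source reports. "The series", "measured", "known", "first", "only" and "open" are said of these compounds alone.

In a functional assay on HT-29 cells (Homo sapiens) for inhibition, read by MTT assay, with a stated time of 48 h (a lower number here means a stronger inhibitor, a higher number a weaker inhibitor), compound 3 `COc1cc(/C=C/c2ccc(NC(=O)/C=C/c3ccc([N+](=O)[O-])cc3)cc2)cc(OC)c1` gives 10700 nM, the highest number of the three measured compounds. Compound 1 `COc1cc(/C=C/c2ccc(NC(=O)/C=C/c3ccc(OC)c(OC)c3)cc2)cc(OC)c1` gives 960 nM, and compound 2 `COc1cc(/C=C/c2ccc(NC(=O)/C=C/c3ccc(C#N)cc3)cc2)cc(OC)c1` gives 3320 nM. Compound 4 `COc1cc(/C=C/c2ccc(NC(=O)/C=C/c3ccccc3F)cc2)cc(OC)c1` differs from compound 3 by 2-fluorophenyl in place of 4-nitrophenyl on a double-bonded chain carbon bound to a double-bonded chain carbon. Within the data shown here, no measured step swaps in a 2-fluorophenyl, but two steps bear on the change: an 11-fold higher number from compound 1 to compound 3 (1.05 log units; beyond the scatter) and a 3.2-fold higher number from compound 2 to compound 3 (0.51 log units; beyond the scatter), both showing that the 4-nitrophenyl carries the highest number among the measured groups. A modest step to a lower number is therefore expected for compound 4, estimated as a 3.1-fold lower number from compound 3 to compound 4 (0.49 log units; beyond the scatter). Compound 4 is accordingly expected to give about 3500 nM, in a range from 1000 nM to 12000 nM.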

Compound 4, half-maximal inhibitory concentration: 2820 nM
Compound 4: the middle estimate sits 1.2-fold (0.09 log units) above what was measured; low and high end bracket the measured number.
By their numbers in this assay, from the lowest: compound 1; then compounds 4 and 2 (each within the scatter of the next); then compound 3.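

In this assay, the 2-fluorophenyl improves on the 4-nitrophenyl, with a 3.8-fold lower number from compound 3 to compound 4 (0.58 log units; beyond the scatter), so this position tolerates a group that carries neither a nitro nor a methoxy substituent. It cannot be told apart from the 4-cyanophenyl, with a 1.2-fold lower number from compound 2 to compound 4 (0.07 log units; within the scatter), yet it still falls short of the 3,4-dimethoxyphenyl, with a 2.9-fold higher number from compound 1 to compound 4 (0.47 log units; beyond the scatter). No measurement offered here explains these differences.

The compounds shown leave open how an amine or a carboxylic acid on this phenyl ring would compare. They also do not separate the effect of changing the substituent from that of changing where it sits.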